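Aryl Exchange on a Weakly Antiproliferative Core

The source may hold more compounds than are shown below. What is called first, only, known or untested is meant among the compounds shown, and "the series" means these compounds.

Among the compounds with values here, in a functional assay on KB cells (Homo sapiens) for antiproliferative activity, read by sulforhodamine B assay, with a stated time of 3 days (a lower number here means that less compound is needed, a higher number that more compound is needed for the effect), compound 2 `CCC1=C(O)c2c(oc(-c3ccc(C)c(Cl)c3)cc2=O)C(CC)(CC)C1=O` gives 39 uM, the only actual number so far. Compound 1 `CCC1=C(O)c2c(oc(-c3ccc(SC)cc3)cc2=O)C(CC)(CC)C1=O` is reported only as a limit, > 52.1 uM.

Compound 3 `CCC1=C(O)c2c(oc(-c3ccc(OC)c(F)c3)cc2=O)C(CC)(CC)C1=O` keeps the shared core of compound 2 but carries 3-fluoro-4-methoxyphenyl in place of 3-chloro-4-methylphenyl, on the aromatic carbon next to the ring oxygen (3-fluoro-4-methoxyphenyl in place of 3-chloro-4-methylphenyl on an aromatic carbon). Within the data shown here, one measured step bears on this change, since it exchanges the aryl group at the same place: an at least 1.3-fold lower number from compound 1 to compound 2 (0.12 log units; that floor lies within the scatter). That step rests on (the limit of > 52.1 uM in this assay, at which 1 of the 2 values shown sits), so it gives only a floor and no true size. No shift beyond the scatter is therefore expected in this assay. The expected change is a 1.0-fold higher number from compound 2 to compound 3 (0.01 log units; within the scatter), with no clear direction. For compound 3 the estimated value is 40 uM, with an expected range from 18 uM to 85 uM.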

Compound 3, concentration for half-maximal effect: 26.7 uM
Beside the measured number, compound 3's estimate is 1.5-fold (0.18 log units) above it, within the range that was stated.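

In this assay, an aryl exchange on this aromatic carbon now has a true size, where the earlier step gave only a floor (a 1.5-fold lower number from compound 2 to compound 3 (0.16 log units; within the scatter)). Putting 3-fluoro-4-methoxyphenyl in place of 3-chloro-4-methylphenyl adds a hydrogen-bond acceptor to the count, yet the number does not move beyond the usual scatter. On these data alone, the comparison with 4-(methylsulfanyl)phenyl stays open-ended (an at least 1.9-fold lower number from compound 1 to compound 3 (0.29 log units; that floor lies within the scatter)), and this is again only a floor, set by a limit: the limit of > 52.1 uM in this assay, at which 1 of the 3 values shown sits.

The three aryl groups shown therefore cannot be ranked in this assay, and no substituent is yet tied to a clear change in the number. As far as these compounds go, whether an amine or a carboxylic acid on the aryl ring, or a longer chain on the shared core, would move the number beyond the scatter remains open.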